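Cytotoxicity of compound 4, expected from compound 1

The source may report more compounds than this note shows. Statements on the series, on what has been measured and on what is new or still open speak of the compounds shown alone.

Among the measured compounds shown here, compound 1 `CC1(C)CC(=O)N(c2cnn3c2CN(C(=O)Nc2cc(F)c(F)c(F)c2)C(C2CC2)C3)C1` is the one compound among the three measured that gives a definite number in a toxicity assay on HepG2 2.2.15 cells (Homo sapiens) for cytotoxicity, read by CellTiter-Glo; a higher number here means that more compound is tolerated, a lower number that less compound is tolerated: compound 1 gives 115000 nM. Compound 2 `C[C@H]1Cn2ncc(N3CC(c4ccccc4)CC3=O)c2CN1C(=S)Nc1cc(F)c(F)c(F)c1` reaches only a limit of this assay, > 2000 nM. Compound 3 `O=C1CC(c2ccccc2)CN1c1cnn2c1CN(C(=O)Nc1cc(F)c(F)c(F)c1)C(Cc1ccccc1)C2` likewise reaches only a limit in this assay, > 2000 nM. The two limits sit at the same place, (the limit of > 2000 nM in this assay, at which 2 of the 3 values shown sit), so they say nothing about how compound 2 and compound 3 compare with compound 1 or with each other.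

Compound 4 `Cc1nc(C2CC(=O)N(c3cnn4c3CN(C(=O)Nc3cc(F)c(F)c(F)c3)C(C3CC3)C4)C2)no1` differs from compound 1 in one place: 4-(5-methyl-1,2,4-oxadiazol-3-yl)-2-oxopyrrolidin-1-yl in place of 4,4-dimethyl-2-oxopyrrolidin-1-yl on an aromatic carbon. For the measured compounds named here, no pair of measured compounds differs in a single place, so no measured step shows how this assay answers such a change. The expectation for compound 4 is therefore a cautious one: a step of a 1.4-fold lower number from compound 1 to compound 4 (0.16 log units; within the scatter) that stays within the usual scatter, or at most a modest loss of tolerance. Compound 4 is estimated at 80000 nM, with a range from 30000 nM to 200000 nM.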

Compound 4, half-maximal cytotoxic concentration: > 200000 nM
Compound 4 ended at the assay's limit; the forecaster's own chance of this, stated with the estimate: 30%; middle value at least 2.5-fold (0.39 log units) away from the limit.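

this assay now has a first single-place change at this aromatic carbon, and it gives an at least 1.7-fold higher number from compound 1 to compound 4 (0.24 log units; that floor lies within the scatter). So swapping 4,4-dimethyl-2-oxopyrrolidin-1-yl for 4-(5-methyl-1,2,4-oxadiazol-3-yl)-2-oxopyrrolidin-1-yl, which adds a five-membered aromatic ring, brings no sign of lost tolerance, something the lower limits of compound 2 and compound 3 could not show. In this assay compound 4 gives > 200000 nM, which is a limit and not a number: the limit of > 200000 nM in this assay, at which 1 of the 4 values shown sits.

As far as these compounds go, how far compound 4 lies past that limit stays open, and with it whether tolerance truly rises at all, since the floor of the step lies within the scatter. From the compounds shown here alone, it is also open whether a primary amine or a carboxylic acid in place of the 5-methyl-1,2,4-oxadiazol-3-yl group would be tolerated as well.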